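One Aryl Swap on a Shared Core, Awaiting Measurement

A few compounds are considered here, and "the series" means these few. Any claim that something is new, unique, unknown or untested is made for them only; others in the source may bear on it.

Measured so far:
compound 1 `O=C1O[C@H]([C@@H](O)Cn2cc(-c3ccc(Br)cc3)nn2)C(OCc2ccccc2)=C1OCc1ccccc1` gives 5620 nM in a functional assay on MCF7 cells (Homo sapiens) for antiproliferative activity, read by MTT assay, with a stated time of 72 h; a higher number here means a weaker inhibitor, a lower number a stronger inhibitor;
compound 2 `O=C1O/C(=C\Cn2cc(-c3cc(C(F)(F)F)cc(C(F)(F)F)c3)nn2)C(OCc2ccccc2)=C1OCc1ccccc1` gives > 100000 nM in this assay.

Among the compounds with values here, compound 1 holds the only actual number here. The value for compound 2 is a limit of the assay, not a number (the limit of > 100000 nM in this assay, at which 1 of the 2 values shown sits). Compound 3 `O=C1O[C@H]([C@@H](O)Cn2cc(CNS(=O)(=O)c3ccc(Cl)cc3)nn2)C(OCc2ccccc2)=C1OCc1ccccc1` differs from compound 1 in one place: (((4-chlorophenyl)sulfonyl)amino)methyl in place of 4-bromophenyl on an aromatic carbon. Within the data shown here, no measured pair shows what such a swap does, so the expectation rests on the change alone. The step is expected to be a 2.7-fold higher number from compound 1 to compound 3 (0.43 log units; beyond the scatter), a modest weakening that may not clear the scatter. Compound 3 is therefore estimated at 15000 nM, within 3000 nM to 80000 nM.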

Compound 3, half-maximal inhibitory concentration: 4170 nM
Compound 3: middle estimate off by 3.6-fold (0.56 log units), on the high side; the measured number falls inside the stated range.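

The step in this assay is a 1.3-fold lower number from compound 1 to compound 3 (0.13 log units; within the scatter) and so shows no real difference between the two compounds. This place on the five-membered ring therefore accepts (((4-chlorophenyl)sulfonyl)amino)methyl, which brings more heavy atoms and a hydrogen-bond donor that 4-bromophenyl lacks, with no step beyond the scatter. Nothing shown here gives a reason for this result.

On these data alone, whether an amine or a carboxylic acid at this place would give a similar number stays open. So does whether the aromatic ring of either group matters, which a plain methyl group there could test.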